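Methoxycarbonyl to Ethylcarbamoyl: Expected Cytotoxicity of Compound 3

The compounds below may be only part of what the source reports. "The series", "measured", "known", "first", "only" and "open" are said of these compounds alone.

Compound 1 `Cc1cn([C@@H]2O[C@H](CO[Si](C)(C)C(C)(C)C)[C@@]3(OS(=O)(=O)C=C3NC(N)=O)[C@H]2O[Si](C)(C)C(C)(C)C)c(=O)n(C)c1=O` is measured in a functional assay on HEL cells (Homo sapiens) for cytotoxicity, read by microscopy (on this read-out lower numbers stand for higher toxicity in this test and higher numbers for lower toxicity in this test), at 16000 nM. Compound 2 `COC(=O)NC1=CS(=O)(=O)O[C@@]12[C@@H](CO[Si](C)(C)C(C)(C)C)O[C@@H](n1cc(C)c(=O)n(C)c1=O)[C@@H]2O[Si](C)(C)C(C)(C)C` in this assay gives >= 50000 nM, which is a limit of the assay and not a number. Compound 2 thus sits at the limit of >= 50000 nM in this assay, at which 1 of the 2 values shown sits, the top of the numbers shown. Going by the values given here, the only measured step, an at least 3.1-fold higher number from compound 1 to compound 2 (0.49 log units; beyond the scatter), bears on compound 3 `CCNC(=O)NC1=CS(=O)(=O)O[C@@]12[C@@H](CO[Si](C)(C)C(C)(C)C)O[C@@H](n1cc(C)c(=O)n(C)c1=O)[C@@H]2O[Si](C)(C)C(C)(C)C`, which differs from compound 2 by ethylamino in place of methoxy on a carbonyl carbon, returning to a carbamoyl-type nitrogen as in compound 1. In this assay compound 3 is expected to give an estimated 30000 nM, between 10000 nM and 60000 nM. That corresponds to an expected step of an at least 1.6-fold lower number from compound 2 to compound 3 (0.22 log units; that floor lies within the scatter).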

Compound 3, minimum cytotoxic concentration: >= 3200 nM
Compound 3: a limit, no number; the forecaster's own chance of this, stated with the estimate: 50%; the middle value does not contradict the limit.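

In this assay compound 3 gives >= 3200 nM, a limit and not a number, so its steps from compound 1 and compound 2 cannot be read. On these data alone, whether ethylamino in place of methoxy changes the read-out stays open.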